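The source may report more compounds than this note shows. Statements on the series, on what has been measured and on what is new or still open speak of the compounds shown alone.

Of the compounds shown here, three share one core and have been tested in an ADME assay on Huh-7 cells (Homo sapiens) for cytotoxicity, read by MTT assay, with a stated time of 72 h; a lower number here means that less compound is tolerated, a higher number that more compound is tolerated. Compound 1 `COc1ccc(-c2cc(C(F)(F)F)c3c(N)c(C(N)=O)sc3n2)cc1` gives 46400 nM. Compound 2 `COc1ccccc1-c1cc(C(F)(F)F)c2c(N)c(C(N)=O)sc2n1` differs from compound 1 only in how the same atoms are joined: 2-methoxyphenyl in place of 4-methoxyphenyl on an aromatic carbon. In this assay compound 2 gives only a limit, > 20000 nM. The step between them is a step that the limit leaves unreadable from compound 1 to compound 2. Compound 3 `COc1ccc(-c2ccc3c(N)c(C(N)=O)sc3n2)cc1` differs from compound 1 by hydrogen in place of trifluoromethyl on an aromatic carbon. In this assay compound 3 reaches a limit, < 400 nM. The change gives an at least 110-fold lower number from compound 1 to compound 3 (2.06 log units; beyond the scatter). Compound 4 `COc1ccccc1-c1ccc2c(N)c(C(N)=O)sc2n1` carries the same kind of change relative to compound 2, (hydrogen in place of trifluoromethyl on an aromatic carbon); around the place, the hydrogen sits meta to a 2-methoxyphenyl group rather than meta to a 4-methoxyphenyl group. Beside that earlier step, an expected step of an at least 25-fold lower number from compound 2 to compound 4 (1.39 log units; beyond the scatter) rests on compound 1 giving 46400 nM and on the step of an at least 110-fold lower number from compound 1 to compound 3 (2.06 log units; beyond the scatter). Compound 4 is estimated at 800 nM, between 150 nM and 4000 nM.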

Compound 4, half-maximal cytotoxic concentration: > 20000 nM
Compound 4: a limit, no number; the forecaster's own chance of this, stated with the estimate: 35%; at least 25-fold (1.39 log units) between middle value and limit.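

For the compounds shown here, compound 2 and compound 4 each give only a limit in this assay, so no step between them can be read. The compounds shown leave open what size of change hydrogen in place of trifluoromethyl brings alongside a 2-methoxyphenyl group.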